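Ester variation in the electroshock series

A few compounds are considered here, and "the series" means these few. Any claim that something is new, unique, unknown or untested is made for them only; others in the source may bear on it.

Of the compounds shown here, two have been measured in a functional assay on the whole organism with Rattus norvegicus as the target, in the maximal electroshock model; on this read-out lower numbers stand for an effect already at smaller amounts and higher numbers for an effect only at larger amounts of compound. Compound 1 `Cc1cccc(C)c1NC(=O)c1conc1C` gives 8.9 mg/kg. Compound 2 `CCOC(=O)C1C(=O)C=C(Nc2cc(C)on2)CC1C` gives 68.9 mg/kg, the higher of the two numbers; the gap to compound 1 lies beyond the scatter of repeated measurements, so compound 2 stands as the less favourable of the pair in this assay.

Compound 3 `Cc1cc(NC2=CC(=O)C(C(=O)OC(C)(C)C)C(C)C2)no1` has not been measured. Relative to compound 2 it differs in one place: tert-butyl in place of ethyl on an oxygen next to a carbonyl group. The change keeps the donor and acceptor count unchanged and adds no ring.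

Going by the values given here, no measured pair in the set shows what this exchange does in this assay, so there is no basis for expecting a shift in either direction beyond the scatter. Compound 3 is therefore expected to sit close to compound 2, with a step of a 1.0-fold higher number from compound 2 to compound 3 (0.01 log units; within the scatter) expected to stay within the usual scatter. The estimate for compound 3 is 70 mg/kg, with a range from 35 mg/kg to 140 mg/kg.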

Compound 3, dose for half-maximal effect: 28.1 mg/kg
The estimate for compound 3 lay 2.5-fold (0.40 log units) above the measured number; measured number below the stated range.
By their numbers in this assay, from the lowest: compound 1; then compound 3; then compound 2.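

The ester position is not silent in this assay: tert-butyl in place of ethyl on an oxygen next to a carbonyl group gives a 2.5-fold lower number from compound 2 to compound 3 (0.39 log units; beyond the scatter) and so moves the read-out towards an effect at smaller amounts of compound. Going by these compounds alone, this is the only single-place step so far, so the direction holds for this one pair and cannot yet be called a trend. No measurement on hand bears on what lies behind the step.

Open, as far as these compounds go, is how the read-out behaves for other esters on the same oxygen, such as isopropyl or benzyl, and whether it follows the count of carbons in the group at all. A carboxylic acid or a primary amide in place of the ester would show whether the ester itself is required for the effect.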